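A few compounds are considered here, and "the series" means these few. Any claim that something is new, unique, unknown or untested is made for them only; others in the source may bear on it.

Measured compounds in an ADME assay on L02 cells (Homo sapiens) for antiproliferative activity, read by MTT assay, with a stated time of 48 h; on this read-out lower numbers stand for stronger inhibition and higher numbers for weaker inhibition:
- compound 1, `N#CC1=C(N)Oc2c(c3nc4ccccc4nc3c3ccccc23)C12C(=O)N(Cc1cnnn1-c1cccc(Cl)c1)c1ccccc12`: compound 1 gives 35200 nM.
- compound 2, `N#CC1=C(N)Oc2c(c3nc4ccccc4nc3c3ccccc23)C12C(=O)N(Cc1cnnn1-c1ccc([N+](=O)[O-])cc1)c1ccccc12`: compound 2 reaches only the limit of the measurement, > 50000 nM, which is a ceiling and not a number.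
- compound 3, `N#CC1=C(N)Oc2c(c3nc4ccccc4nc3c3ccccc23)C12C(=O)N(Cc1cnnn1-c1ccc(S(N)(=O)=O)cc1)c1ccccc12`: compound 3 likewise sits at the limit, > 50000 nM.

Compound 3 therefore stands at the limit of > 50000 nM in this assay, at which 2 of the 3 values shown sit, so no finite number is known for it, and the comparison with compound 2 is a step that the two limits leave unreadable from compound 2 to compound 3.

The next compound, compound 4, `Cc1ccc(-n2nncc2CN2C(=O)C3(C(C#N)=C(N)Oc4c3c3nc5ccccc5nc3c3ccccc43)c3ccccc32)cc1C`, changes only the aryl group hanging from the triazole nitrogen: 3,4-dimethylphenyl in place of 4-sulfamoylphenyl on an aromatic nitrogen. Two measured steps alter that same aryl group and so bear on this change: an at least 1.4-fold higher number from compound 1 to compound 2 (0.15 log units; that floor lies within the scatter) and an at least 1.4-fold higher number from compound 1 to compound 3 (0.15 log units; that floor lies within the scatter). From the compounds shown here alone, both moved from a finite number to the ceiling, so their true size is unknown, and neither shows a readable shift beyond the scatter. Within the data shown here, nothing among the measured compounds points toward a stronger inhibition for a dimethylphenyl group.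

Compound 4 is therefore expected to land near the limit again, with an estimated value of 45000 nM in this assay, most plausibly between 20000 nM and 100000 nM. That corresponds to an expected step of an at least 1.1-fold lower number from compound 3 to compound 4 (0.04 log units; that floor lies within the scatter), which is not expected to go beyond the scatter.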

Compound 4, half-maximal inhibitory concentration: > 50000 nM
Compound 4: a limit, no number; the forecaster's own chance of this, stated with the estimate: 55%; middle value at least 1.1-fold (0.04 log units) away from the limit.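

In this assay compound 4 gives > 50000 nM, which is a limit and not a number. Among these compounds, the limit is therefore not confined to aryl groups carrying nitro or sulfamoyl, since 3,4-dimethylphenyl, made of carbon only, reaches it on this aromatic nitrogen too; compound 1 goes against this pattern with its finite value, yet the only readable step to the new compound is an at least 1.4-fold higher number from compound 1 to compound 4 (0.15 log units; that floor lies within the scatter), while the steps from compound 2 and compound 3 to compound 4 cannot be read. Among these aryl groups, the ceiling is now the usual result: the limit of > 50000 nM in this assay, at which 3 of the 4 values shown sit.

Whether compound 2, compound 3 and compound 4 truly differ stays hidden, as none of them has a finite value. From the compounds shown here alone, it also remains open how an aminophenyl or carboxyphenyl group on this nitrogen, or a longer chain in place of the aryl ring, would read in this assay.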